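A Phenyl-Bearing Acid in Place of 2-Carboxyethyl

A few compounds are considered here, and "the series" means these few. Any claim that something is new, unique, unknown or untested is made for them only; others in the source may bear on it.

In a functional assay on K562 cells (Homo sapiens) for cytotoxicity, read by trypan blue exclusion, with a stated time of 96 h (a lower number here means a stronger inhibitor, a higher number a weaker inhibitor), compound 3 (`COc1cc(OC)c(/C=C/S(=O)(=O)Cc2ccc(OC)c(NCCC(=O)O)c2)c(OC)c1`) gives 5000 nM, the highest number of the three compounds measured. Compound 1 (`COC(=O)[C@H](C)Nc1cc(CS(=O)(=O)/C=C/c2c(OC)cc(OC)cc2OC)ccc1OC`) gives 200 nM, and compound 2 (`COC(=O)C(Nc1cc(CS(=O)(=O)/C=C/c2c(OC)cc(OC)cc2OC)ccc1OC)c1ccc(Cl)cc1`) gives 200 nM.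

Compound 4 (`COc1cc(OC)c(/C=C/S(=O)(=O)Cc2ccc(OC)c(NC(C(=O)O)c3ccccc3)c2)c(OC)c1`) differs from compound 3 in one place: carboxy(phenyl)methyl in place of 2-carboxyethyl on a nitrogen on an aromatic ring. Carboxy(phenyl)methyl thus stands in place of 2-carboxyethyl on a nitrogen on an aromatic ring.

Going by the values given here, three measured steps bear on this change. The swap of 1-(methoxycarbonyl)ethyl for (4-chlorophenyl)(methoxycarbonyl)methyl gave no change at the digits printed from compound 1 to compound 2 (within the scatter), so a group carrying an aromatic ring was matched by no shift in this pair of methyl esters. The large steps of a 25-fold higher number from compound 1 to compound 3 (1.40 log units; beyond the scatter) and a 25-fold higher number from compound 2 to compound 3 (1.40 log units; beyond the scatter) both end at the 2-carboxyethyl group, but each replaces the whole group, so the data cannot separate the ester from the rest of the change. Compound 4 keeps a free carboxy group, as compound 3 does, while its carboxy(phenyl)methyl group resembles the group of compound 2. Among the compounds with values here, no measured compound shows that combination.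

A moderate move towards a lower number is therefore expected, as a 5.0-fold lower number from compound 3 to compound 4 (0.70 log units; beyond the scatter). The estimated value for compound 4 is 1000 nM, with an expected range from 200 nM to 5000 nM.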

Compound 4, half-maximal inhibitory concentration: 15 nM
Estimate against measurement, compound 4: 67-fold (1.82 log units) above; measured number outside the range, below it.
By their numbers in this assay, from the lowest: compound 4; then compounds 1 and 2 (each within the scatter of the next); then compound 3.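

At this position, on a nitrogen on an aromatic ring, a free carboxy group does not by itself go with a high number: in this assay, carboxy(phenyl)methyl in place of 2-carboxyethyl gives a 330-fold lower number from compound 3 to compound 4 (2.52 log units; beyond the scatter) while keeping that carboxy group. The acid compound 4 also moves past both methyl esters, with a 13-fold lower number from compound 2 to compound 4 (1.12 log units; beyond the scatter) and a 13-fold lower number from compound 1 to compound 4 (1.12 log units; beyond the scatter) as its steps, so the weak result of compound 3 cannot be read as a penalty for every free acid, and compound 4 now has the lowest number of the four, beyond the scatter against each of the others. Nothing measured here accounts for the size of these steps.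

The change from compound 3 to compound 4 brings in the phenyl ring and alters the chain on the nitrogen together, so the compounds shown leave open how much of the step belongs to each. They also leave open whether a 1-carboxyethyl group, with a methyl in place of the phenyl, or a carboxy(4-chlorophenyl)methyl group would keep the low number of compound 4.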